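Benzyl substituent variation, cytotoxicity working notes

The compounds below may be only part of what the source reports. "The series", "measured", "known", "first", "only" and "open" are said of these compounds alone.

Measured so far in an ADME assay on RAW264.7 cells (Mus musculus) for cytotoxicity, read by MTT assay, with a stated time of 72 h, tested at 50 uM; a higher number here means more inhibition at the concentration tested (going by the name of the read-out), a lower number less inhibition:
compound 1 `CCOC(=O)c1sc(-c2ccncc2)nc1N1CCC(NCc2ccccc2)CC1`: 10.8%
compound 2 `CCOC(=O)c1sc(-c2ccncc2)nc1N1CCC(NCc2ccc(OC)cc2)CC1`: 16.1%
compound 3 `CCOC(=O)c1sc(-c2ccncc2)nc1N1CCC(NCc2cccc(C(F)(F)F)c2)CC1`: 14.3%

Compound 3 has the second highest of the three numbers, with compound 2 nearest and compound 1 furthest, both within the scatter. Compound 4 `CCOC(=O)c1sc(-c2ccncc2)nc1N1CCC(NCc2ccc(Cl)c(Cl)c2)CC1` carries a different substituted benzyl group: 3,4-dichlorophenyl in place of 3-(trifluoromethyl)phenyl on a saturated chain carbon bound to an amine nitrogen.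

Among the measured compounds shown here, the steps that bear on this change are the earlier substituent swaps on the same aromatic ring: a number 3.5 percentage points higher from compound 1 to compound 3 (within the scatter) and a number 1.8 percentage points lower from compound 2 to compound 3 (within the scatter), both within the scatter, as was a number 5.3 percentage points higher from compound 1 to compound 2 (within the scatter). No substituent on this ring has so far moved the read-out beyond the scatter, so for compound 4 the expected step is a number 0.7 percentage points higher from compound 3 to compound 4 (within the scatter), none beyond the scatter. Compound 4 is therefore estimated at 15%, expected between 5% and 26%.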

Compound 4, a percentage reported as inhibition, at one concentration (the size of the read-out at that concentration, not a potency): 32.2%
Compound 4: middle estimate off by 17.2 percentage points, on the low side; the whole stated range lies below it.
By their numbers in this assay, from the lowest: compounds 1, 3 and 2 (each within the scatter of the next); then compound 4.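

In this assay, the group on the saturated chain carbon bound to an amine nitrogen is now seen to move the read-out beyond the scatter, with a number 17.9 percentage points higher from compound 3 to compound 4 (beyond the scatter) and a number 16.1 percentage points higher from compound 2 to compound 4 (beyond the scatter) and also a number 21.4 percentage points higher from compound 1 to compound 4 (beyond the scatter) in the same direction. Only the 3,4-dichlorophenyl group stands apart; phenyl, 4-methoxyphenyl and 3-(trifluoromethyl)phenyl remain within the scatter of one another. Nothing available explains this separation.

The compounds shown leave open whether one chlorine alone gives a step of this size. They also leave open whether bromine in place of chlorine does the same.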